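Phenyl in place of (cyanomethyl)carbonyl on the amine nitrogen

This account rests on a few compounds, and the source may have more. Where it says the series, first, only, none or still open, it means among the compounds named here.

Of the compounds shown here, three built on one shared core have been tested in a functional assay on MCF7 cells (Homo sapiens) for cytotoxicity, read by sulforhodamine B assay, with a stated time of 24 h; a lower number here means a stronger inhibitor, a higher number a weaker inhibitor. Compound 1 `N/N=C1\C(=O)Nc2ccc(S(=O)(=O)N3CCOCC3)cc21` gives 46800 nM. Compound 2 `N#CCC(=O)N/N=C1\C(=O)Nc2ccc(S(=O)(=O)N3CCOCC3)cc21` gives 27700 nM. Compound 3 `O=C1Nc2ccc(S(=O)(=O)N3CCOCC3)cc2/C1=N/c1ccc(Br)cc1` gives 44800 nM. Compound 2 sits at the low end of these three numbers, but it is not separated from either neighbour, as the step of a 1.0-fold lower number from compound 1 to compound 3 (0.02 log units; within the scatter) also shows. Compound 4 `O=C1Nc2ccc(S(=O)(=O)N3CCOCC3)cc2/C1=N/Nc1ccccc1` has not yet been measured; it differs from compound 2 in one place: phenyl in place of (cyanomethyl)carbonyl on an amine nitrogen. For the measured compounds named here, two measured steps touch this same nitrogen. Adding the (cyanomethyl)carbonyl to hydrogen gave a 1.7-fold lower number from compound 1 to compound 2 (0.23 log units; within the scatter), and exchanging the whole ((cyanomethyl)carbonyl)amino for 4-bromophenyl gave a 1.6-fold higher number from compound 2 to compound 3 (0.21 log units; within the scatter). Going by the values given here, every change at this position so far has left the number roughly where it was, so for compound 4 in this assay the expected step is a 1.3-fold higher number from compound 2 to compound 4 (0.10 log units; within the scatter), nothing beyond the scatter. Compound 4 is therefore estimated at 35000 nM, with a likely range from 12000 nM to 100000 nM.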

Compound 4, half-maximal inhibitory concentration: 30300 nM
Estimate against measurement, compound 4: 1.2-fold (0.06 log units) above, within the range that was stated.
By their numbers in this assay, from the lowest: compounds 2, 4, 3 and 1 (each within the scatter of the next).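

The phenyl puts a ring on the amine nitrogen, which compounds 1 to 3 lack there, and in this assay this exchange for (cyanomethyl)carbonyl stays within the scatter (a 1.1-fold higher number from compound 2 to compound 4 (0.04 log units; within the scatter)). The same holds when phenyl takes the place of hydrogen on that nitrogen (a 1.5-fold lower number from compound 1 to compound 4 (0.19 log units; within the scatter)), so a ring of carbon only, a chain carrying hydrogen-bond acceptors and a bare hydrogen cannot be told apart here. Anilino in place of 4-bromophenyl on the double-bonded nitrogen also stays within the scatter (a 1.5-fold lower number from compound 3 to compound 4 (0.17 log units; within the scatter)).

Still open, going by these compounds, is whether a substituent on this phenyl ring, such as a carboxylic acid or an amine, or a longer chain on the amine nitrogen, would move the number beyond the scatter. No measurement shown here explains why these compounds read alike.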